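The compounds below may be only part of what the source reports. "The series", "measured", "known", "first", "only" and "open" are said of these compounds alone.

In an in vivo ADME assay on the whole organism for pharmacokinetics, with Rattus norvegicus as the target, at a dose of 5 mg/kg by the oral route (a lower number here means that a smaller share of the oral dose reaches the circulation, a higher number that a larger share of the oral dose reaches the circulation), compound 1 `CCC(CC)[C@@H]1C(=O)N[C@H](C2Cc3ccccc3C2)C(=O)N1[C@@H](C(=O)N1CCOCC1)c1ccc(C)nc1` gives 55%, the highest of three numbers, against compound 2 `CCC(CC)[C@@H]1C(=O)N[C@H](C2Cc3ccccc3C2)C(=O)N1[C@@H](C(=O)N1CCOCC1)c1ccc(C)nc1C` at 42% and compound 3 `CCC(CC)[C@@H]1C(=O)N[C@H](C2Cc3ccccc3C2)C(=O)N1[C@@H](C(=O)N(C)C)c1ccc(C)nc1` at 36%. Compound 4 `CC[C@H](C)[C@@H]1C(=O)N[C@H](C2Cc3ccccc3C2)C(=O)N1[C@@H](C(=O)N1CCOCC1)c1ccc(C)nc1` differs from compound 1 in one place: sec-butyl in place of pentan-3-yl on a saturated ring carbon, with sec-butyl in place of pentan-3-yl on a saturated ring carbon. Neither measured step touches that place. Methyl in place of hydrogen on an aromatic carbon gave a number 13 percentage points lower from compound 1 to compound 2 (beyond the scatter), and dimethylamino in place of morpholin-4-yl gave a number 19 percentage points lower from compound 1 to compound 3 (beyond the scatter). These steps show only what single changes elsewhere did, so a slight fall within the scatter is expected here. The expected step is a number 5 percentage points lower from compound 1 to compound 4 (within the scatter). For compound 4 the estimated value is 50%, with an expected range of 33% to 66%.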

Compound 4, oral bioavailability: 54%
Beside the measured number, compound 4's estimate is 4 percentage points below it; the measured number falls inside the stated range.
By their numbers in this assay, from the lowest: compounds 3 and 2 (each within the scatter of the next); then compounds 4 and 1 (each within the scatter of the next).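

In this assay, sec-butyl in place of pentan-3-yl on this saturated ring carbon gives a number 1 percentage points lower from compound 1 to compound 4 (within the scatter), so the two groups cannot be told apart here. Unlike the two earlier steps, made elsewhere on the molecule, this change to the chain, which also brings one defined stereocentre, leaves no difference beyond the scatter. Nothing at hand explains this result.

Still open, from the compounds shown here alone, is whether a plain methyl, a cyclohexyl ring or a chain bearing an amine at this carbon would give a similar number. The other stereoisomer of sec-butyl also remains an open case.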